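Chloro to bromo swap on a two-compound splenocyte set

The source may hold more compounds than are shown below. What is called first, only, known or untested is meant among the compounds shown, and "the series" means these compounds.

Measured so far:
compound 1 `CO/C(=C\c1ccc(Cl)cc1)C(=O)Nc1ccc(Br)cc1`: 11000 nM
compound 2 `CO/C(=C\c1ccc(OC)cc1)C(=O)Nc1ccc(Cl)cc1`: 14700 nM

In a functional assay on cells (Splenocyte, Mus musculus, strain BALB/c) for inhibition, read by MTT assay, with a stated time of 48 h (on this read-out lower numbers stand for stronger inhibition and higher numbers for weaker inhibition), compound 1 gives 11000 nM and compound 2 gives 14700 nM. Compound 2 stands at the higher of the two numbers, but its gap to compound 1 is within the scatter, so nothing is read from it. Compound 3 `CO/C(=C\c1ccc(OC)cc1)C(=O)Nc1ccc(Br)cc1` is not yet measured. It differs from compound 2 by bromo in place of chloro on an aromatic carbon. Among the compounds with values here, no measured pair covers this exchange, and the two values shown differ only within the scatter, so the step from compound 2 to compound 3 is expected to stay within the scatter, with no direction called. For compound 3 the estimate in this assay is 12000 nM, range 6000 nM to 25000 nM. The expected step is a 1.2-fold lower number from compound 2 to compound 3 (0.09 log units; within the scatter).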

Compound 3, half-maximal inhibitory concentration: 1770 nM
Beside the measured number, compound 3's estimate is 6.8-fold (0.83 log units) above it; measured number outside the range, below it.
By their numbers in this assay, from the lowest: compound 3; then compounds 1 and 2 (each within the scatter of the next).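

In this assay the 4-chlorophenyl to 4-bromophenyl change gives an 8.3-fold lower number from compound 2 to compound 3 (0.92 log units; beyond the scatter) and so shows that this position can distinguish the two halogens, which the earlier pair could not show. With bromo kept, swapping chloro for methoxy gives a 6.2-fold lower number from compound 1 to compound 3 (0.79 log units; beyond the scatter) and only the pairing of methoxy with bromo stands apart from the other two compounds. Open, as far as these compounds go, is whether the bromo gain holds with other groups in place of methoxy, and what iodo or an amine would give at the same position. Nothing at hand accounts for either step.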